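This account rests on a few compounds, and the source may have more. Where it says the series, first, only, none or still open, it means among the compounds named here.

Three compounds share one core and differ only in the group on a triple-bonded carbon. Compound 1 `Cc1ccccc1C#Cc1ccc(C(=O)N[C@H](C)C(C)(C)O)nc1` gives 59.9% in a functional assay on HEK293 cells for positive allosteric modulation of metabotropic glutamate receptor 5 (Rattus norvegicus), read by fluorescence and calcium flux; a higher number here means a larger maximal response, a lower number a smaller maximal response; compound 2 `Cc1nc(C#Cc2ccc(C(=O)N[C@H](C)C(C)(C)O)nc2)cs1` gives 66.6%; compound 3 `C[C@@H](NC(=O)c1ccc(C#CC2CC2)cn1)C(C)(C)O` gives 63.4%. Compound 3 stands second highest of the three numbers. The steps of a number 3.5 percentage points higher from compound 1 to compound 3 (within the scatter) and a number 3.2 percentage points lower from compound 2 to compound 3 (within the scatter) both lie within the scatter. Compound 4 `C[C@@H](NC(=O)c1ccc(C#Cc2cccc(F)n2)cn1)C(C)(C)O` is not yet measured and differs from compound 3 by 6-fluoropyridin-2-yl in place of cyclopropyl on a triple-bonded carbon. The two steps that bear on this change each put cyclopropyl in place of an aromatic ring and moved the number only within the scatter, so an aromatic ring entering in place of cyclopropyl is expected to change this assay little. For compound 4 the expected step is therefore a number 0.4 percentage points lower from compound 3 to compound 4 (within the scatter). Compound 4 is estimated at 63%, with a range from 50% to 76%.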

Compound 4, largest response reached (reported as efficacy), in percent of the reference or control that the assay uses: 63%
Compound 4: middle estimate and measured number agree at the digits printed, and the stated range covers the measured number.
By their numbers in this assay, from the lowest: compounds 1, 4, 3 and 2 (each within the scatter of the next).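

Compound 4 places a six-membered aromatic ring with one hetero atom and a fluorine on the triple-bonded carbon, and this assay still separates it from none of the other three groups: the steps are a number 0.4 percentage points lower from compound 3 to compound 4 (within the scatter) and a number 3.6 percentage points lower from compound 2 to compound 4 (within the scatter) and a number 3.1 percentage points higher from compound 1 to compound 4 (within the scatter). All four groups at this position therefore give values within the scatter of one another. Nothing shown explains this flat response.

Still open, as far as these compounds go, is whether an amine, a carboxylic acid or a longer carbon chain on the triple-bonded carbon would give a step beyond the scatter. The largest response also does not show what concentration each compound needs to reach it.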